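This account rests on a few compounds, and the source may have more. Where it says the series, first, only, none or still open, it means among the compounds named here.

Series notes. Compound 1 `CCO[C@]1(c2ccc(OCc3c(-c4c(Cl)cccc4Cl)noc3C3CC3)cc2Cl)C[C@H](c2cccc(C(=O)O)c2)C1` and compound 2 `O=C(O)c1cncc(N2CC(O)(c3ccc(OCc4c(-c5c(Cl)cccc5Cl)noc4C4CC4)cc3Cl)C2)c1` share the large side chain and differ in the central ring and in the acid-bearing aromatic group. In an assay on HEK293 cells for agonist activity at Bile acid receptor (Homo sapiens) (on this read-out higher numbers stand for an effect only at larger amounts of compound and lower numbers for an effect already at smaller amounts), compound 1 gives 220 nM; in this assay compound 2 gives 552 nM, the higher of the two numbers, and the gap between them lies beyond the scatter. Compound 3 `O=C(O)c1cccc(N2CC(O)(c3ccc(OCc4c(-c5c(Cl)cccc5Cl)noc4C4CC4)cc3Cl)C2)c1` keeps the core of compound 2 and changes only the acid-bearing ring: 3-carboxyphenyl in place of 5-carboxypyridin-3-yl on an amine nitrogen in a ring. Going by the values given here, no measured pair in the set shows this exact change on this core; the only guide is that compound 1, which carries the same 3-carboxyphenyl group on a different core, gives the lower number. A modest step toward a lower number is therefore expected, a 1.6-fold lower number from compound 2 to compound 3 (0.20 log units; within the scatter), though an outcome within the scatter would not be surprising. Compound 3 is estimated at 350 nM in this assay, with a range of 150 nM to 900 nM.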

Compound 3, half-maximal effective concentration: 86 nM
For compound 3 the middle estimate is 4.1-fold (0.61 log units) above the measured one; measured number outside the range, below it.
By their numbers in this assay, from the lowest: compound 3; then compound 1; then compound 2.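

In this assay, going by these compounds alone, placing 3-carboxyphenyl in place of 5-carboxypyridin-3-yl on an amine nitrogen in a ring gives a 6.4-fold lower number from compound 2 to compound 3 (0.81 log units; beyond the scatter) and is the first change that can be read at a single place. The two groups have the same heavy-atom count, and the entering ring is carbon only, with one hydrogen-bond acceptor fewer, so this position responds to a change of one ring atom in the acid-bearing group. Nothing at hand accounts for the size of this step.

From the compounds shown here alone, whether the same change gives a similar step on the core of compound 1 remains open. Also open, going by these compounds, is how a primary amide or a tetrazole would read in place of the carboxylic acid on the phenyl ring.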